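Methoxy for Ethyl on the Phenyl of an Endothelin Antagonist

The source may report more compounds than this note shows. Statements on the series, on what has been measured and on what is new or still open speak of the compounds shown alone.

Of the compounds shown here, two have been measured. Compound 1 `COc1cccc(Oc2c(NS(=O)(=O)c3ccc(C(C)(C)C)cc3)ncnc2OCCOc2nccs2)c1` gives 12 nM in an assay on cells (Endothelial cell) for binding affinity to Endothelin-1 receptor (Sus scrofa); on this read-out lower numbers stand for stronger inhibition and higher numbers for weaker inhibition. Compound 2 `CCc1ccc(-c2c(NS(=O)(=O)c3ccc(C(C)(C)C)cc3)ncnc2OCCOc2ncc(SC)cn2)cc1` gives 0.013 nM in this assay, the lowest of the two numbers; the nearest number, that of compound 1, is higher by a gap well beyond the scatter. Compound 3 `COc1ccc(-c2c(NS(=O)(=O)c3ccc(C(C)(C)C)cc3)ncnc2OCCOc2ncc(SC)cn2)cc1` has not yet been measured; it differs from compound 2 in one place only: methoxy in place of ethyl on an aromatic carbon. Among the compounds with values here, no pair of measured compounds that differ in just one place exists here, so the size of this step cannot be read from the data. Given the small size of the exchange, the step from compound 2 to compound 3 is expected to be modest, a 2.3-fold higher number from compound 2 to compound 3 (0.36 log units; beyond the scatter), perhaps slightly toward a higher number. For compound 3 the expected value in this assay is 0.03 nM, with a range from 0.005 nM to 0.2 nM.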

Compound 3, half-maximal inhibitory concentration: < 0.001 nM
Compound 3: a limit, no number; the forecaster's own chance of this, stated with the estimate: 2%; middle value at least 30-fold (1.47 log units) from the limit.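

Methoxy in place of ethyl, on the aromatic carbon para to a large group, gives in this assay an at least 13-fold lower number from compound 2 to compound 3 (1.11 log units; beyond the scatter). Within the data shown here, this is the first single-place comparison, and it shows that this position responds strongly to an exchange of two heavy atoms for two, with one hydrogen-bond acceptor entering. Compound 3 stands at a limit of the assay and not at a number, so the step is only a minimum and its full size remains unknown: the limit of < 0.001 nM in this assay, at which 1 of the 3 values shown sits.

The compounds shown leave open whether the step depends on the oxygen itself, and how a hydroxyl, an ethoxy or a dimethylamino group would read at this place. Compound 1 differs from compound 2 in more than one place, so it cannot show whether the exchange would carry over to other members of the series.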